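Swapping 4-(trifluoromethyl)phenyl for 3-chlorophenyl: working notes

The compounds below may be only part of what the source reports. "The series", "measured", "known", "first", "only" and "open" are said of these compounds alone.

Measured so far in a functional assay on GBM2 cells (Homo sapiens) for antiproliferative activity, read by WST assay, with a stated time of 72 h; on this read-out higher numbers stand for weaker inhibition and lower numbers for stronger inhibition
- compound 1 `O=C(Nc1cccc(Cl)c1)Nc1cc2ncncc2cc1OCc1ccccc1Cl` gives 2100 nM
- compound 2 `O=C(Nc1ccc(C(F)(F)F)cc1)Nc1cc2ncncc2cc1OCc1ccccc1` gives 8600 nM

Compound 2 stands higher of the two at 8600 nM, beyond the scatter from compound 1. Compound 3 `O=C(Nc1cccc(Cl)c1)Nc1cc2ncncc2cc1OCc1ccccc1` has 3-chlorophenyl in place of 4-(trifluoromethyl)phenyl on an amide-type nitrogen. The expectation rests on compound 1, which also carries 3-chlorophenyl and gives 2100 nM, although it differs from compound 3 elsewhere too. In this assay a lower number is expected, an estimated 2.3-fold lower number from compound 2 to compound 3 (0.35 log units; beyond the scatter), modestly beyond the scatter. The estimate for compound 3 is 3800 nM (expected range 1500 nM to 9000 nM).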

Compound 3, half-maximal inhibitory concentration: 4100 nM
Beside the measured number, compound 3's estimate is 1.1-fold (0.03 log units) below it, within the range that was stated.
By their numbers in this assay, from the lowest: compounds 1 and 3 (each within the scatter of the next); then compound 2.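

In this assay, the change at the amide-type nitrogen can now be read alone: 3-chlorophenyl in place of 4-(trifluoromethyl)phenyl gives a 2.1-fold lower number from compound 2 to compound 3 (0.32 log units; beyond the scatter), a modest step. Hydrogen in place of chloro on an aromatic carbon gives a 2.0-fold higher number from compound 1 to compound 3 (0.29 log units; within the scatter), so that change does not separate from the scatter. Nothing at hand gives a reason for either step.

Open, going by these compounds, is how an aminomethyl group or a carboxylic acid on the phenyl at the amide-type nitrogen would read. Also open, on these data alone, is how a methoxy group in place of that chloro would read.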